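This account rests on a few compounds, and the source may have more. Where it says the series, first, only, none or still open, it means among the compounds named here.

Three compounds share one core and differ only in what hangs from the hydrazide end. In a functional assay on MCF7 cells (Homo sapiens) for cytotoxicity, read by MTT assay, with a stated time of 48 h (on this read-out higher numbers stand for weaker inhibition and lower numbers for stronger inhibition), compound 1 `NNC(=O)CSc1nnc(-c2ccncc2)o1` gives 3260 nM. Compound 2 `O=C(CSc1nnc(-c2ccncc2)o1)N/N=C/c1ccc(Br)cc1` gives 19100 nM, and compound 3 `Cc1ccc(/C=N/NC(=O)CSc2nnc(-c3ccncc3)o2)cc1` gives 14700 nM, the second highest of the three numbers, close to compound 2 and well apart from compound 1. The step of a 1.3-fold lower number from compound 2 to compound 3 (0.11 log units; within the scatter) lies within the scatter. Compound 4 `O=C(CSc1nnc(-c2ccncc2)o1)N/N=C/c1cc(Cl)cc(Cl)c1O` differs from compound 3 by 3,5-dichloro-2-hydroxyphenyl in place of 4-methylphenyl on a carbon with a double bond to nitrogen. Going by the values given here, only that one small step touches this aryl group; nothing measured speaks to the hydroxy group or the chlorines. Compound 4 is therefore expected to move little, a 1.1-fold lower number from compound 3 to compound 4 (0.02 log units; within the scatter), to an estimated 14000 nM with a range from 5000 nM to 40000 nM.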

Compound 4, half-maximal inhibitory concentration: 5920 nM
Compound 4: the middle estimate sits 2.4-fold (0.37 log units) above what was measured; measured number inside the range.
By their numbers in this assay, from the lowest: compounds 1 and 4 (each within the scatter of the next); then compounds 3 and 2 (each within the scatter of the next).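

In this assay, this position, on a carbon with a double bond to nitrogen, proves sensitive to the choice of aryl group: 3,5-dichloro-2-hydroxyphenyl brings a 2.5-fold lower number from compound 3 to compound 4 (0.39 log units; beyond the scatter) against 4-methylphenyl and a 3.2-fold lower number from compound 2 to compound 4 (0.51 log units; beyond the scatter) against 4-bromophenyl, whereas methyl in place of bromo had stayed within the scatter. Nothing available explains this change. The compounds shown leave open whether the hydroxy group or the chlorines carry the step. From the compounds shown here alone, what an amine or a carboxylic acid on this aryl group would give also remains open.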